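This account rests on a few compounds, and the source may have more. Where it says the series, first, only, none or still open, it means among the compounds named here.

Of the compounds shown here, three of a shared core have been measured in a functional assay (B cells) with Mus musculus as the target; a higher number here means that more compound is needed for the effect, a lower number that less compound is needed. Compound 1 `C=CCn1c(=O)n(C2CCC(CO)C2)c2nc(N)nc(O)c21` gives 226 uM in this assay, compound 3 `Nc1nc(O)c2c(n1)n(C1OC(CO)[C@@H](O)[C@H]1O)c(=O)n2CC(O)CSc1ccccc1` gives 142 uM, and compound 2 `C=CCn1c(=O)n(CCCCCCCC)c2nc(N)nc(O)c21` gives 37 uM. On these numbers compound 2 stands lowest of the three: the nearest is compound 3, whose value is higher by a margin beyond the scatter, and the furthest is compound 1, higher still and also beyond the scatter. None of these pairs differ in only one place, so the comparisons show only what the values themselves show.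

Compound 4 `C=CCn1c(=O)n(CCCC)c2nc(N)nc(O)c21` has not yet been measured in this assay. It differs from compound 2 in one place: hydrogen in place of butyl on a saturated chain carbon, four bonds along the chain from an aromatic nitrogen. The chain on that nitrogen is thus shorter by the butyl that leaves. Among the measured compounds, the one carrying the longest plain chain, compound 2, gives the lowest number, while compound 1 and compound 3 with their more polar substituents give higher ones. On that basis the account expects the step of a 3.0-fold higher number from compound 2 to compound 4 (0.47 log units; beyond the scatter) to run toward a higher number, of a size beyond the scatter but modest. For compound 4 the estimate in this assay is 110 uM, with a range from 40 uM to 320 uM.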

Compound 4, concentration for half-maximal effect: 2 uM
Estimate against measurement, compound 4: 55-fold (1.74 log units) above; measured number outside the range, below it.
By their numbers in this assay, from the lowest: compound 4; then compound 2; then compounds 3 and 1 (each within the scatter of the next).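

In this assay, taking the butyl off the saturated chain gives a 19-fold lower number from compound 2 to compound 4 (1.27 log units; beyond the scatter), so on this aromatic nitrogen the longer plain chain is not the better one, at least for this pair, and chain length alone moves the number by a large step with the rest of the molecule unchanged. The comparison with the ring-bearing substituent gives a 110-fold lower number from compound 1 to compound 4 (2.05 log units; beyond the scatter), where the group of 4 carbon atoms without a ring replaces the five-membered carbon ring with its oxygen-bearing side group, although this change alters both the ring and the oxygen at once and so cannot assign the step to either one. Nothing available explains why the shorter chain needs so much less compound in this assay.

Only two plain chain lengths are shown, so it remains open whether the number would keep falling with a shorter propyl or ethyl chain, or whether it would turn upward somewhere between butyl and the longer chain of compound 2, for example at a hexyl chain. From the compounds shown here alone, it is also open how a hydroxyl group or an amine at the end of the butyl chain would change the value of compound 4.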